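A few compounds are considered here, and "the series" means these few. Any claim that something is new, unique, unknown or untested is made for them only; others in the source may bear on it.

Measured compounds:
compound 1, `O=C(Nc1ccccc1)Nc1cccc(CNc2nccnc2Cl)c1`: 16300 nM
compound 2, `COc1ccccc1NC(=O)Nc1cccc(CNc2nccnc2Cl)c1`: 12200 nM
compound 3, `Cc1ccc(NC(=O)Nc2cccc(CNc3nccnc3Cl)c2)c(C)c1`: 10100 nM

In a functional assay on MGC-803 cells (Homo sapiens) for antiproliferative activity, read by MTT assay, with a stated time of 48 h (on this read-out lower numbers stand for stronger inhibition and higher numbers for weaker inhibition), compound 1 gives the highest of the three numbers shown, though compound 2 and compound 3 both lie within the scatter of it. Compound 4, `O=C(Nc1cccc(CNc2nccnc2Cl)c1)Nc1ccc(Cl)cc1Br`, differs from compound 1 by 2-bromo-4-chlorophenyl in place of phenyl on an amide-type nitrogen. Within the data shown here, two measured steps bear on this change, both substitutions on the phenyl held by the amide-type nitrogen: a 1.3-fold lower number from compound 1 to compound 2 (0.13 log units; within the scatter) and a 1.6-fold lower number from compound 1 to compound 3 (0.21 log units; within the scatter), each within the scatter. A third step, a 1.2-fold lower number from compound 2 to compound 3 (0.08 log units; within the scatter), was likewise within the scatter. The expected step is therefore a 1.7-fold lower number from compound 1 to compound 4 (0.23 log units; within the scatter), small, toward a lower number if anything, and not clearly beyond the scatter. For compound 4 the estimate in this assay is 9500 nM, in the range 4000 nM to 22000 nM.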

Compound 4, half-maximal inhibitory concentration: 7480 nM
Estimate against measurement, compound 4: 1.3-fold (0.10 log units) above; the range from low to high includes it.
By their numbers in this assay, from the lowest: compounds 4, 3, 2 and 1 (each within the scatter of the next, the first and the last beyond it).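

In this assay, among these compounds, 2-bromo-4-chlorophenyl on the amide-type nitrogen gives the first step that lies beyond the scatter (a 2.2-fold lower number from compound 1 to compound 4 (0.34 log units; beyond the scatter)). Against the other substituted phenyl groups, the change stays within the scatter (a 1.4-fold lower number from compound 3 to compound 4 (0.13 log units; within the scatter); a 1.6-fold lower number from compound 2 to compound 4 (0.21 log units; within the scatter)), so the new group separates only from unsubstituted phenyl. No measurement available bears on a cause for this step.

Which of the two halogens in 2-bromo-4-chlorophenyl carries the step stays open. Also open, as far as these compounds go, is the response to an amine or a carboxylic acid on that phenyl, or to a longer chain in its place.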